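Ester chain variation in a dihydropyridine calcium channel series

The source may hold more compounds than are shown below. What is called first, only, known or untested is meant among the compounds shown, and "the series" means these compounds.

Measured so far:
compound 1 `CCOC(=O)C1=C(C)NC(C)=C(C(=O)OC)C1c1[nH]c(CC)nc1Cl` gives 2.02 nM
compound 2 `CCCOC(=O)C1=C(C)NC(C)=C(C(=O)OC)C1c1[nH]c(CC)nc1Cl` gives 0.146 nM

In an assay on ileum for inhibition of Voltage-dependent L-type calcium channel subunit alpha-1C (Cavia porcellus) (on this read-out lower numbers stand for stronger inhibition and higher numbers for weaker inhibition), compound 1 stands at the highest of the two numbers; its nearest neighbour is compound 2, reached by a 14-fold lower number from compound 1 to compound 2 (1.14 log units; beyond the scatter). Going by the values given here, that single step, a methyl in place of hydrogen on the saturated chain carbon two bonds along the chain from an ester oxygen, is the only measured change in the set and it is large.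

Compound 3 `CCOC(=O)C1=C(C)NC(C)=C(C(=O)OC(C)C)C1c1[nH]c(CC)nc1Cl` differs from compound 1 by isopropyl in place of methyl on an oxygen next to a carbonyl group. This is a growth of the ester alkyl group at the other ester of the shared core, so the step from compound 1 to compound 2 bears on it only by analogy: the chain is branched rather than extended, and it sits on the other ester. A smaller step in the same direction is therefore expected, as a 3.4-fold lower number from compound 1 to compound 3 (0.53 log units; beyond the scatter) in this assay. Compound 3 is estimated at 0.6 nM, with a range from 0.15 nM to 2.5 nM.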

Compound 3, half-maximal inhibitory concentration: 0.564 nM
Compound 3: middle estimate off by 1.1-fold (0.03 log units), on the high side; the range from low to high includes it.
By their numbers in this assay, from the lowest: compound 2; then compound 3; then compound 1.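

In this assay, isopropyl in place of methyl on an oxygen next to a carbonyl group gives a 3.6-fold lower number from compound 1 to compound 3 (0.55 log units; beyond the scatter), so a second place on the shared core also responds to growth of the alkyl group, and this growth can be branched rather than extended. The earlier change, a 14-fold lower number from compound 1 to compound 2 (1.14 log units; beyond the scatter), showed this direction at one place only; both changes made from compound 1 now lead to a lower number in this assay. Nothing at hand bears on the reason for this shift.

Going by these compounds, compounds 2 and 3 differ in two places, so their values give no clean comparison of the two sites, and it remains open whether the two changes would add up on a single compound. Also open, on these data alone, is how either place would respond to a longer chain such as butyl, or to a chain ending in an amine.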